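The source may hold more compounds than are shown below. What is called first, only, known or untested is meant among the compounds shown, and "the series" means these compounds.

In a functional assay on trachea (Cavia porcellus) (on this read-out lower numbers stand for stronger inhibition and higher numbers for weaker inhibition), compound 1 `CCCN1CC[C@@]2(OC)OC(N)=C(C#N)[C@@H](c3ccccc3)[C@@H]2C1` gives 20700 nM and compound 2 `CO[C@@]12CCN(Cc3ccccc3)C[C@H]1[C@H](c1ccccc1)C(C#N)=C(N)O2` gives 22600 nM; compound 1 thus stands within the scatter of compound 2, the gap being a 1.1-fold higher number from compound 1 to compound 2 (0.04 log units; within the scatter). Compound 3 `CCCN1CC[C@@]2(OC)OC(N)=C(C#N)[C@@H](c3ccc(C)cc3)[C@@H]2C1` differs from compound 1 by methyl in place of hydrogen on an aromatic carbon. For the measured compounds named here, the one measured step bears only loosely on this change, because a 1.1-fold higher number from compound 1 to compound 2 (0.04 log units; within the scatter) concerns a different place and stayed within the scatter; no step at this aromatic ring is known. In this assay no shift beyond the scatter is therefore expected. Compound 3 is expected to give 20000 nM, between 7000 nM and 60000 nM, an expected step of a 1.0-fold lower number from compound 1 to compound 3 (0.01 log units; within the scatter).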

Compound 3, half-maximal inhibitory concentration: 21000 nM
Estimate against measurement, compound 3: 1.1-fold (0.02 log units) below; the measured number falls inside the stated range.
By their numbers in this assay, from the lowest: compounds 1, 3 and 2 (each within the scatter of the next).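

For the compounds shown here, this is the first reading at the aromatic ring rather than on the amine nitrogen: in this assay, going from phenyl to 4-methylphenyl leaves the number within the scatter (a 1.0-fold higher number from compound 1 to compound 3 (0.01 log units; within the scatter)). A single methyl on this aromatic carbon, para to a large group, therefore separates compound 3 from compound 1 by no measurable margin in this read-out. No available evidence bears on this result.

Open, on these data alone, is whether a larger or differently built group at this carbon, such as a methoxy group, a carboxylic acid or an amine, would shift the number beyond the scatter. Also open, as far as these compounds go, is whether a methyl on another carbon of this ring would read the same.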